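Two stereocentres redrawn: compound 1 to compound 3

A few compounds are considered here, and "the series" means these few. Any claim that something is new, unique, unknown or untested is made for them only; others in the source may bear on it.

Measured compounds:
compound 1 `CC(C)C[C@@H](NC(=O)OC(C)(C)C)C(=O)N1CCC[C@H]1C(=O)N1[C@H](C(=O)OCc2ccccc2)[C@H]1C(=O)OCc1ccccc1`: > 100000 nM
compound 2 `CC(C)C[C@H](NC(=O)OC(C)(C)C)C(=O)N1CCC(C(=O)N2[C@H](C(=O)O)[C@H]2C(=O)O)CC1`: "not determined" (no result reported)

In a functional assay on J774 cells (Mus musculus) for cytotoxicity, with a stated time of 48 h (on this read-out lower numbers stand for stronger inhibition and higher numbers for weaker inhibition), compound 1 gives > 100000 nM, which is a limit and not a number. Compound 2 gives "not determined" (no result reported), so it offers no comparison. The next compound to be tested is compound 3 `CC(C)C[C@H](NC(=O)OC(C)(C)C)C(=O)N1CCC[C@@H]1C(=O)N1[C@H](C(=O)OCc2ccccc2)[C@H]1C(=O)OCc1ccccc1`. It is built from the same pieces as compound 1, and only the three-dimensional arrangement at some atoms differs: the two compounds have the same atoms and bonds and differ only in configuration as drawn: 2 of 4 stereo elements differ; a stereocentre at a saturated chain carbon is drawn R in compound 1 and S in compound 3; a stereocentre at a saturated ring carbon is drawn S in compound 1 and R in compound 3. A stereocentre at a saturated chain carbon is drawn R in compound 1 and S in compound 3, and a stereocentre at a saturated ring carbon is drawn S in compound 1 and R in compound 3.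

Going by the values given here, no measured pair shows what such a change does. The expectation rests on compound 1 alone, whose result of > 100000 nM is a limit. No step beyond the usual scatter is expected in this assay, and the estimated change is a number no higher from compound 1 to compound 3 (the limit leaves the size open). For compound 3 the expected value is 100000 nM, with an estimated range from 40000 nM to 200000 nM.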

Compound 3, half-maximal inhibitory concentration: > 100000 nM
Compound 3 was reported as a limit; the forecaster's own chance of this, stated with the estimate: 75%; the middle value sits exactly at the limit.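

In this assay no step can be read between compound 1 and compound 3, because each result is only a limit and not a number: the limit of > 100000 nM in this assay, at which 2 of the 3 values shown sit.

Going by these compounds, whether redrawing these two stereocentres changes cytotoxicity at all stays open, since neither compound has a measured value.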